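This account rests on a few compounds, and the source may have more. Where it says the series, first, only, none or still open, it means among the compounds named here.

Compound 1 `CC(C)C(=O)N1CC2CC(C1)N2` and compound 2 `O=C(CC1C=CCC1)N1CC2CC(C1)N2` share the same core and differ only in the group carried on the carbonyl carbon. In an assay on CHO cells for agonist activity at Neuronal acetylcholine receptor; alpha3/alpha6/beta2/beta3 (Homo sapiens), read by FLIPR and calcium flux (on this read-out higher numbers stand for larger maximal responses and lower numbers for smaller maximal responses), compound 1 gives 45%. In this assay compound 2 gives 47%. Among the compounds with values here, of the two numbers known so far, compound 1 is the lower one, but its distance to compound 2 lies within the usual scatter of such measurements, so the two values show no real difference between them. Within the data shown here, no step between two measured compounds that differ in a single place has been worked out, so nothing yet tells how strongly a change on the carbonyl carbon moves the largest response.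

Compound 3 `C[C@H]1C[C@H]1C(=O)N1CC2CC(C1)N2` has not been measured. It differs from compound 1 in one place: 2-methylcyclopropyl in place of isopropyl on a carbonyl carbon. Both measured compounds, with quite different groups on that carbonyl carbon, give values close to each other, which suggests the step of a number 2 percentage points higher from compound 1 to compound 3 (within the scatter) is expected to stay within the scatter, in no clear direction. Compound 3 is therefore estimated to reach 47%. For compound 3 the expected range runs from 32% to 62%.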

Compound 3, largest response reached (Emax), in percent of the reference or control that the assay uses: 60%
Compound 3: middle estimate off by 13 percentage points, on the low side, and the stated range covers the measured number.
By their numbers in this assay, from the lowest: compounds 1 and 2 (each within the scatter of the next); then compound 3.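

Within the data shown here, putting 2-methylcyclopropyl in place of isopropyl on a carbonyl carbon gives a number 15 percentage points higher from compound 1 to compound 3 (beyond the scatter) in this assay, so this is the first sign that the largest response depends on the group at this position. Compounds 1 and 2 alone could not show this, as their values lie within the scatter of each other despite their quite different groups, whereas here a modest change is enough: one three-membered carbon ring and two defined stereocentres enter, while hydrogen-bond donors and acceptors stay absent on both sides. The result shows only that the response moves with this swap, and nothing available here gives a reason for the rise.

The compounds shown leave open whether the step belongs to the three-membered ring, to its methyl group or to the particular arrangement at the two stereocentres, a question that plain cyclopropyl and the other stereoisomers of 2-methylcyclopropyl could help to separate. Going by these compounds, it also remains open how this position would respond to a group of a different kind, such as an amine or a longer carbon chain.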